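The compounds below may be only part of what the source reports. "The series", "measured", "known", "first", "only" and "open" are said of these compounds alone.

Of the compounds shown here, three have been measured in an assay on isolated protein for inhibition of DNA topoisomerase 1 (Homo sapiens), with a stated time of 15 min; a lower number here means a stronger inhibitor, a higher number a weaker inhibitor. Compound 1 `CN[C@@H]1CCN(c2cc3c(cc2F)c(=O)c(C(=O)O)cn3Cc2ccc(-c3ccccc3)cc2)C1` gives 34800 nM, the lowest of the three numbers. Compound 3 `COc1c(N2CC[C@@H](CN)C2)c(F)cc2c(=O)c(C(=O)O)cn(Cc3ccc(-c4ccc(F)cc4)cc3)c12` gives 60900 nM, which lies within the scatter of compound 1, so no order between the two can be read. Compound 2 `O=C(O)c1cn(Cc2ccc(-n3cccn3)cc2)c2cc(NC[C@H]3CCNC3)c(F)cc2c1=O` gives 187000 nM, beyond the scatter relative to compound 1. Compound 4 `NC[C@@H]1CCN(c2cc3c(cc2F)c(=O)c(C(=O)O)cn3Cc2ccc(-c3ccccc3)cc2)C1` is not yet measured; it differs from compound 1 by aminomethyl in place of methylamino on a saturated ring carbon, the same atoms joined differently. For the measured compounds named here, no measured pair shows this change, so its effect is unknown. The expected step, a 1.1-fold higher number from compound 1 to compound 4 (0.06 log units; within the scatter), is small, with no direction beyond the scatter. Compound 4 is estimated at 40000 nM, between 15000 nM and 110000 nM.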

Compound 4, half-maximal inhibitory concentration: 15600 nM
Compound 4: the middle estimate sits 2.6-fold (0.41 log units) above what was measured; the range from low to high includes it.
By their numbers in this assay, from the lowest: compound 4; then compounds 1 and 3 (each within the scatter of the next); then compound 2.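

In this assay, 3-(methylamino)pyrrolidin-1-yl to 3-(aminomethyl)pyrrolidin-1-yl gives a 2.2-fold lower number from compound 1 to compound 4 (0.35 log units; beyond the scatter), a modest step. For the compounds shown here, this is the first pair to isolate a change at this saturated ring carbon, and it shows that the number responds to how the same atoms are joined, with the heavy-atom count unchanged. No supporting data bear on what lies behind the step.

As far as these compounds go, a longer chain ending in an amine, such as aminoethyl, remains open at this ring carbon, as does a dimethylamino group. From the compounds shown here alone, whether the step carries over to other groups on the shared core also remains open.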